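Swapping 3,4-dichlorophenyl for 3-bromophenyl on a shared core

This account rests on a few compounds, and the source may have more. Where it says the series, first, only, none or still open, it means among the compounds named here.

In a functional assay on HepG2 cells (Homo sapiens) for cytotoxicity, read by MTT assay, with a stated time of 24 h (on this read-out lower numbers stand for stronger inhibition and higher numbers for weaker inhibition), compound 1 (`CN1C/C(=C\c2cccc([N+](=O)[O-])c2)C(=O)/C(=C/c2ccccc2F)C1`) gives 1080 nM while compound 2 (`CN1C/C(=C\c2ccc(Cl)cc2)C(=O)/C(=C/c2cccc([N+](=O)[O-])c2)C1`) gives 8210 nM and compound 3 (`CN1C/C(=C\c2cccc([N+](=O)[O-])c2)C(=O)/C(=C/c2ccc(Cl)c(Cl)c2)C1`) gives 5960 nM on the same test. Compound 3 stands level with compound 2, the gap being a 1.4-fold lower number from compound 2 to compound 3 (0.14 log units; within the scatter), and apart from compound 1, the gap being a 5.5-fold higher number from compound 1 to compound 3 (0.74 log units; beyond the scatter). Compound 2 stands equally apart from compound 1, with a 7.6-fold higher number from compound 1 to compound 2 (0.88 log units; beyond the scatter). Compound 4 (`CN1C/C(=C\c2cccc(Br)c2)C(=O)/C(=C/c2cccc([N+](=O)[O-])c2)C1`) alters one group of compound 3: 3-bromophenyl in place of 3,4-dichlorophenyl on a double-bonded chain carbon bound to a double-bonded ring carbon. The step that added a chloro group to compound 2 stayed within the scatter, so no step beyond the scatter is expected in this assay here, and the estimated step is a 1.3-fold lower number from compound 3 to compound 4 (0.12 log units; within the scatter). For compound 4 the expected value is 4500 nM, with an estimated range from 1500 nM to 11000 nM.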

Compound 4, half-maximal inhibitory concentration: 4890 nM
Compound 4: middle estimate off by 1.1-fold (0.04 log units), on the low side, and the stated range covers the measured number.
By their numbers in this assay, from the lowest: compound 1; then compounds 4, 3 and 2 (each within the scatter of the next).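

In this assay, a bromine-bearing ring at this position reads the same as the chlorine-bearing rings: the change gives a 1.2-fold lower number from compound 3 to compound 4 (0.09 log units; within the scatter) and also a 1.7-fold lower number from compound 2 to compound 4 (0.23 log units; within the scatter). The 2-fluorophenyl ring of compound 1 is the exception, with a 4.5-fold higher number from compound 1 to compound 4 (0.66 log units; beyond the scatter). Three different halogen patterns on this ring therefore now sit together, and only compound 1 goes against that pattern. From the compounds shown here alone, whether a ring bearing an amine or a carboxylic acid here would sit with compound 1 or with the others remains open. Nothing available explains why compound 1 stands apart.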